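From three inactive analogues to a trifluorophenyl variant

This account rests on a few compounds, and the source may have more. Where it says the series, first, only, none or still open, it means among the compounds named here.

Compound 3 `CC(C)[C@H](NC(=O)COc1cccc2ccccc12)C(=O)N[C@@H](CC(=O)O)C(=O)COc1cccc(F)c1` carries a 3-fluorophenyl group on an oxygen on a saturated carbon. In a functional assay on Jurkat cells (Homo sapiens) (on this read-out lower numbers stand for stronger inhibition and higher numbers for weaker inhibition), compound 3 gives only a limit of the assay, > 100000 nM, and no number. Its two neighbours share that fate. Compound 1 `CC(C)[C@H](NC(=O)COc1cccc2ccccc12)C(=O)N[C@@H](CC(=O)O)C(=O)COc1ccc2ccccc2c1` bears a naphthalen-2-yl group at the same oxygen. In this assay compound 1 gives a limit, > 100000 nM. Compound 2 `CC(C)[C@H](NC(=O)COc1cccc2ccccc12)C(=O)N[C@@H](CC(=O)O)C(=O)COc1ccccc1F` bears a 2-fluorophenyl group there. In this assay compound 2 also gives a limit, > 100000 nM. The steps among these three cannot be read: a step that the two limits leave unreadable from compound 1 to compound 2, a step that the two limits leave unreadable from compound 1 to compound 3 and a step that the two limits leave unreadable from compound 2 to compound 3, all because of the limit of > 100000 nM in this assay, at which 3 of the 3 values shown sit. Compound 4 `CC(C)[C@H](NC(=O)COc1cccc2ccccc12)C(=O)N[C@@H](CC(=O)O)C(=O)COc1cc(F)c(F)cc1F` differs from compound 3 in one place: 2,4,5-trifluorophenyl in place of 3-fluorophenyl on an oxygen on a saturated carbon. Going by the values given here, no measured step bears on this change beyond the three unreadable ones, and every group tried so far in that place has left the read-out at the limit. The step that the limit leaves unreadable from compound 3 to compound 4 is therefore expected to be small, if readable at all. Compound 4 is estimated at 150000 nM, with a range from 30000 nM to 1000000 nM, and most probably only a limit will again be reported.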

Compound 4, half-maximal inhibitory concentration: 39300 nM
Estimate against measurement, compound 4: 3.8-fold (0.58 log units) above; the measured number falls inside the stated range.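

At this oxygen on a saturated carbon, the 2,4,5-trifluorophenyl group gives the only readable number among the compounds shown in this assay, with an at least 2.5-fold lower number from compound 3 to compound 4 (0.40 log units; beyond the scatter), an at least 2.5-fold lower number from compound 2 to compound 4 (0.40 log units; beyond the scatter) and an at least 2.5-fold lower number from compound 1 to compound 4 (0.40 log units; beyond the scatter). Each of these sizes is only a minimum because the other compound in each pair sits at a limit: the limit of > 100000 nM in this assay, at which 3 of the 4 values shown sit. The position therefore does respond to the group placed on the oxygen, although compound 1, compound 2 and compound 3 cannot be ranked against one another.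

Going by these compounds, whether a difluorophenyl or a pentafluorophenyl group at this oxygen would lower the number further remains open. Also open, on these data alone, is whether the same change would carry over if an ester replaced the carboxylic acid of the shared core.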